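Nitro to methoxy on the shared core

The compounds below may be only part of what the source reports. "The series", "measured", "known", "first", "only" and "open" are said of these compounds alone.

In a functional assay on MV4-11 cells (Homo sapiens) for inhibition, read by resazurin assay, with a stated time of 72 h (on this read-out lower numbers stand for stronger inhibition of growth and higher numbers for weaker inhibition of growth), two compounds have been measured so far. Compound 1 `NS(=O)(=O)c1cccc(Nc2ncc3c(n2)CCCC3)c1` gives 2550 nM, and compound 2 `O=[N+]([O-])c1cccc(Nc2ncc3c(n2)CCCC3)c1` gives 3500 nM. Among the compounds with values here, compound 2 therefore stands within the scatter of compound 1, its only neighbour on the numbers, and the two cannot be ranked.

Compound 3 `COc1cccc(Nc2ncc3c(n2)CCCC3)c1` is the next to be read. It has methoxy in place of nitro on an aromatic carbon, meta to a large group: methoxy in place of nitro on an aromatic carbon.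

Within the data shown here, one measured step bears on this change, as it involves the same aromatic carbon, with nitro in place of sulfamoyl. That step is a 1.4-fold higher number from compound 1 to compound 2 (0.14 log units; within the scatter). Among the measured compounds shown here, it is a single pair, and no measured compound yet carries methoxy, so the evidence is thin. For the measured compounds named here, with that step as the only guide, no change beyond the scatter is expected in this assay, and no direction can be assigned. The expected result is a 1.2-fold lower number from compound 2 to compound 3 (0.07 log units; within the scatter). Compound 3 is estimated at 3000 nM, with an expected range of 1200 nM to 8000 nM.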

Compound 3, concentration for 50% growth inhibition: 2280 nM
Estimate against measurement, compound 3: 1.3-fold (0.12 log units) above, and the stated range covers the measured number.
By their numbers in this assay, from the lowest: compounds 3, 1 and 2 (each within the scatter of the next).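

In this assay this aromatic carbon, meta to a large group, has now carried three different groups on the shared core, and methoxy in place of nitro gives a 1.5-fold lower number from compound 2 to compound 3 (0.19 log units; within the scatter) while methoxy in place of sulfamoyl gives a 1.1-fold lower number from compound 1 to compound 3 (0.05 log units; within the scatter) on the same read-out. Methoxy brings 2 heavy atoms and 1 hydrogen-bond acceptor where nitro has 3 heavy atoms and 2 hydrogen-bond acceptors, yet this difference in count leaves the number within the scatter, so sulfamoyl, nitro and methoxy cannot be ranked at this position. No data on these compounds offer an explanation for this flat picture.

Going by these compounds, whether an amine, a carboxylic acid or a longer chain such as butoxy on this aromatic carbon would move the number beyond the scatter remains open. Also open, on these data alone, is whether sulfamoyl, nitro or methoxy would read differently on another carbon of the same aromatic ring, or with the shared core itself altered, since all three compounds vary in one place only.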